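This account rests on a few compounds, and the source may have more. Where it says the series, first, only, none or still open, it means among the compounds named here.

Measured compounds:
compound 1 `O=C(Nc1cccc(-c2oc3cc(-c4ccc(F)cc4)ccc3c(=O)c2O)c1)c1ccc(F)cc1` — 14200 nM
compound 2 `COc1ccc(C(=O)Nc2cccc(-c3oc4cc(-c5ccc(F)cc5)ccc4c(=O)c3O)c2)cc1` — 5490 nM
compound 3 `COc1ccccc1C(=O)Nc1cccc(-c2oc3cc(-c4ccc(F)cc4)ccc3c(=O)c2O)c1` — 9050 nM

In a functional assay on HCC1937 cells (Homo sapiens) for antiproliferative activity, read by CCK-8 assay, with a stated time of 72 h (on this read-out higher numbers stand for weaker inhibition and lower numbers for stronger inhibition), compound 3 stands second highest of the three, within the scatter of both compound 1 and compound 2. Compound 4 `Cc1ccccc1C(=O)Nc1cccc(-c2oc3cc(-c4ccc(F)cc4)ccc3c(=O)c2O)c1` differs from compound 3 by methyl in place of methoxy on an aromatic carbon. Among the measured compounds shown here, no measured step swaps methyl for methoxy; the nearest bearings are a 2.6-fold lower number from compound 1 to compound 2 (0.41 log units; beyond the scatter) and a 1.6-fold higher number from compound 2 to compound 3 (0.22 log units; within the scatter), one modest and one within the scatter, so the changes seen on this amide-bound aryl ring have so far been small. A step of similar size is therefore expected, most likely none beyond the scatter, with direction uncertain: a 1.0-fold lower number from compound 3 to compound 4 (0.00 log units; within the scatter). Compound 4 is estimated at 9000 nM, with a range of 4000 nM to 20000 nM.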

Compound 4, half-maximal inhibitory concentration: 9900 nM
The estimate for compound 4 lay 1.1-fold (0.04 log units) below the measured number; low and high end bracket the measured number.
By their numbers in this assay, from the lowest: compounds 2, 3, 4 and 1 (each within the scatter of the next, the first and the last beyond it).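

In this assay, methyl in place of methoxy ortho to a large group leaves the number essentially unmoved, with a 1.1-fold higher number from compound 3 to compound 4 (0.04 log units; within the scatter). The 2-methylphenyl group also stays within the scatter of the 4-methoxyphenyl and 4-fluorophenyl groups, with a 1.8-fold higher number from compound 2 to compound 4 (0.26 log units; within the scatter) and a 1.4-fold lower number from compound 1 to compound 4 (0.16 log units; within the scatter). No supporting measurement bears on the reason for this result. Going by these compounds, whether an amine or a carboxylic acid on this ring would shift the number beyond the scatter remains open. On these data alone, the effect of a longer chain in place of methyl is also open.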